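This account rests on a few compounds, and the source may have more. Where it says the series, first, only, none or still open, it means among the compounds named here.

Compound 1 `COc1ccccc1-c1nnc(-c2sc(-c3cccnc3)nc2C)o1`: > 100 ug/mL, a limit.
Compound 2 `Cc1nc(-c2cccnc2)sc1-c1nnc(-c2ccc(Cl)cc2)o1`: > 100 ug/mL, a limit.
Compound 3 `Cc1ccccc1-c1nnc(-c2sc(-c3cccnc3)nc2C)o1`: > 100 ug/mL, a limit.

For the measured compounds named here, all three were tested in an ADME assay on THP-1 cells (Homo sapiens) for cytotoxicity, read by MTT assay (a lower number here means that less compound is tolerated, a higher number that more compound is tolerated), and the series so far shows only (the limit of > 100 ug/mL in this assay, at which 3 of the 3 values shown sit). Compound 3 therefore has no number, only the limit > 100 ug/mL.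

Compound 4 `Cc1nc(-c2cccnc2)sc1-c1nnc(-c2ccncc2)o1` carries pyridin-4-yl in place of 2-methylphenyl on an aromatic carbon. Going by the values given here, three measured steps bear on this change: a step that the two limits leave unreadable from compound 2 to compound 3, a step that the two limits leave unreadable from compound 1 to compound 3 and a step that the two limits leave unreadable from compound 1 to compound 2. None of them gives a size or direction, so no step beyond the scatter is expected in this assay. The expected step is a step that the limit leaves unreadable from compound 3 to compound 4. For compound 4 the estimated value is 120 ug/mL, with an expected range of 50 ug/mL to 300 ug/mL.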

Compound 4, half-maximal cytotoxic concentration: > 100 ug/mL
Compound 4 gave a limit, no number; the forecaster's own chance of this, stated with the estimate: 80%; the middle value lies beyond the limit too.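

Compounds 1, 2, 3 and 4 each give only a limit in this assay, so no step among them can be read: the limit of > 100 ug/mL in this assay, at which 4 of the 4 values shown sit.

The compounds shown leave open whether the groups exchanged on the shared core differ in cytotoxicity at all.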